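Trifluoromethyl in place of methoxy on compound 2

The source may hold more compounds than are shown below. What is called first, only, known or untested is meant among the compounds shown, and "the series" means these compounds.

In an ADME assay on THP-1 cells (Homo sapiens) for cytotoxicity, read by flow cytometry and propidium iodide staining, with a stated time of 72 h (a lower number here means a stronger inhibitor, a higher number a weaker inhibitor), compound 2 (`COc1ccc(-c2oc3ccc(NC(C)=O)cc3c(=O)c2OC)cc1`) gives > 50000 nM, which is a limit and not a number. Compound 3 (`COc1c(-c2cccc(F)c2)oc2ccc(NC(C)=O)cc2c1=O`) gives > 125000 nM, which is also a limit. Only compound 1 (`CC(=O)Nc1ccc2oc(-c3ccc(C(F)(F)F)cc3)cc(=O)c2c1`) reads as a number, at 10000 nM. Compound 2 therefore offers no exact starting point.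

Compound 4 (`COc1c(-c2ccc(C(F)(F)F)cc2)oc2ccc(NC(C)=O)cc2c1=O`) has not yet been measured. It differs from compound 2 by one change, trifluoromethyl in place of methoxy on an aromatic carbon, para to a large group. Within the data shown here, the only measured step leaving compound 2 is a step that the two limits leave unreadable from compound 2 to compound 3, and it gives no size to carry over. The nearest guide is compound 1 at 10000 nM, which also carries trifluoromethyl but is not a single-place neighbour of compound 4. That number tilts the expectation slightly towards a stronger reading, though the assay may well return only a limit again. The expected change is an at least 1.1-fold lower number from compound 2 to compound 4 (0.04 log units; that floor lies within the scatter), a small and uncertain move. Compound 4 is estimated at 45000 nM, with an expected range from 15000 nM to 130000 nM.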

Compound 4, half-maximal inhibitory concentration: > 125000 nM
Compound 4: a limit, no number; the forecaster's own chance of this, stated with the estimate: 50%; middle value at least 2.7-fold (0.44 log units) away from the limit.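

In this assay, compound 4 gives > 125000 nM, which is a limit and not a number. The informative comparison keeps the trifluoromethyl and changes the shared core: methoxy in place of hydrogen on an aromatic carbon is an at least 12-fold higher number from compound 1 to compound 4 (1.09 log units; beyond the scatter), so the trifluoromethyl on its own does not preserve the numerical reading seen for compound 1 once that methoxy is present. Changing methoxy to trifluoromethyl on the aromatic carbon para to a large group adds no size that can be stated, and the steps leaving compound 2 cannot be read because they end in limits, as do their starting values: the limit of > 125000 nM in this assay, at which 2 of the 4 values shown sit.

From the compounds shown here alone, how far compound 2, compound 3 and compound 4 really lie above their limits remains open, as does the full size of the step from compound 1, for which only a floor is printed. Also open, going by these compounds, is whether an amine or a carboxylic acid on that same aromatic carbon, with the core methoxy kept, would give a number rather than another limit.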